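The source may report more compounds than this note shows. Statements on the series, on what has been measured and on what is new or still open speak of the compounds shown alone.

The measured compounds:
compound 1 `O=C(CI)NCCCNc1ncnc2c1ncn2[C@@H]1O[C@H](COP(=O)(O)OP(=O)(O)OP(=O)(O)O)[C@@H](O)[C@H]1O` 0%
compound 2 `O=C(CI)NCCCCCCCCNc1ncnc2c1ncn2[C@@H]1O[C@H](COP(=O)(O)OP(=O)(O)OP(=O)(O)O)[C@@H](O)[C@H]1O` 47%
compound 3 `O=C(CI)NCCNc1ncnc2c1ncn2[C@@H]1O[C@H](COP(=O)(O)OP(=O)(O)OP(=O)(O)O)[C@@H](O)[C@H]1O` 0%

All three share one core from which a saturated chain runs to an iodoacetamide group; only the length of that chain differs. In an assay on isolated protein for inhibition of hexokinase-3 (Rattus norvegicus), with a stated time of 6 h, tested at 10 mM (on this read-out higher numbers stand for more inhibition at the one concentration tested (going by the name of the read-out) and lower numbers for less inhibition), compound 1 gives 0%, level with compound 3 at 0%, and together these two are the lowest of the three numbers. Compound 2 gives 47%. Among the compounds with values here, the one large step seen is a number 47 percentage points higher from compound 1 to compound 2 (beyond the scatter), a lengthening of the chain, and its reverse is a number 47 percentage points lower from compound 2 to compound 3 (beyond the scatter); between the two short-chain compounds there is no change at the digits printed from compound 1 to compound 3 (within the scatter).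

Compound 4 `O=C(CI)NCCCCCCC(=O)NCCCNc1ncnc2c1ncn2[C@@H]1O[C@H](COP(=O)(O)OP(=O)(O)OP(=O)(O)O)[C@@H](O)[C@H]1O` differs from compound 1 by 5-(((iodomethyl)carbonyl)amino)pentyl in place of iodo on a saturated chain carbon bound to a carbonyl carbon. This again makes the path from the core to the iodomethyl group much longer, so the step from compound 1 to compound 2 is the one that bears on it, and on that basis a rise is expected. Within the data shown here, no measured compound, however, carries an added amide inside the chain, nor a chain this long, so the estimate is held loosely. The expected step is a number 35 percentage points higher from compound 1 to compound 4 (beyond the scatter), giving an estimate for compound 4 of 35%, with a range from 5% to 65%.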

Compound 4, a percentage reported as inhibition, at one concentration (the size of the read-out at that concentration, not a potency): 0%
Compound 4: middle estimate off by 35 percentage points, on the high side, and the stated range ends above it.
By their numbers in this assay, from the lowest: compounds 1, 3 and 4 (each within the scatter of the next); then compound 2.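

Putting 5-(((iodomethyl)carbonyl)amino)pentyl in place of iodo on a saturated chain carbon bound to a carbonyl carbon gives no change at the digits printed from compound 1 to compound 4 (within the scatter) in this assay, so on this core a much longer path to the iodomethyl group does not by itself go with inhibition. The earlier compounds shown here alone tied inhibition to chain length, with a number 47 percentage points higher from compound 1 to compound 2 (beyond the scatter), but compound 4 goes against that simple reading: its long chain also holds an inner amide, and its number stays level with that of compound 1. No measurement at hand offers a reason for this outcome.

Going by these compounds, it remains open whether the inner amide or the overall chain length separates compound 4 from compound 2, a question that an unbroken chain of methylene groups of the same length as in compound 4, or a chain with an ether oxygen in place of the amide, could address. Also open, on these data alone, is how chains of intermediate length, between those of compound 1 and compound 2, would behave in this assay, since the step from short to long is seen here only as a single jump.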